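Ethylamino to (1,3-thiazol-2-yl)amino on a Shared Core

The compounds below may be only part of what the source reports. "The series", "measured", "known", "first", "only" and "open" are said of these compounds alone.

In a functional assay on SF-268 cells (Homo sapiens) for cytotoxicity, read by MTT assay, with a stated time of 3 days (on this read-out higher numbers stand for weaker inhibition and lower numbers for stronger inhibition), compound 1 (`N#Cc1c(O)nc(SCc2nc3ccccc3[nH]2)nc1-c1ccccc1`) gives 3.2 nM and compound 2 (`N#Cc1c(Cl)nc(SCc2nc3ccccc3[nH]2)nc1-c1ccccc1`) gives 3.2 nM. Chloro in place of hydroxy therefore makes no change at the digits printed from compound 1 to compound 2 (within the scatter). Compound 3 (`CCNc1nc(SCc2nc3ccccc3[nH]2)nc(-c2ccccc2)c1C#N`) has the highest of the three numbers at 7.35 nM, and it is the same distance from the other two.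

Compound 4 (`N#Cc1c(Nc2nccs2)nc(SCc2nc3ccccc3[nH]2)nc1-c1ccccc1`) differs from compound 3 in one place: 1,3-thiazol-2-yl in place of ethyl on a nitrogen on an aromatic ring. Here 1,3-thiazol-2-yl stands in place of ethyl on a nitrogen on an aromatic ring, so ethylamino becomes (1,3-thiazol-2-yl)amino.

Going by the values given here, no measured step changes the group on that nitrogen, so the evidence is indirect. Ethylamino in place of hydroxy gave a 2.3-fold higher number from compound 1 to compound 3 (0.36 log units; beyond the scatter), and ethylamino in place of chloro gave a 2.3-fold higher number from compound 2 to compound 3 (0.36 log units; beyond the scatter). Both steps are modest, and they are the largest seen in this small set. On the strength of those two steps, no change beyond the scatter is expected in this assay, though the wide range allows for a move in either direction. The expected change is a 1.2-fold lower number from compound 3 to compound 4 (0.09 log units; within the scatter). Compound 4 is estimated at 6 nM, with an expected range of 2 nM to 20 nM.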

Compound 4, half-maximal inhibitory concentration: 2.55 nM
Beside the measured number, compound 4's estimate is 2.4-fold (0.37 log units) above it; low and high end bracket the measured number.
By their numbers in this assay, from the lowest: compounds 4, 1 and 2 (each within the scatter of the next); then compound 3.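

In this assay, the group on the nitrogen now has a step of its own: 1,3-thiazol-2-yl in place of ethyl gives a 2.9-fold lower number from compound 3 to compound 4 (0.46 log units; beyond the scatter), a modest change, which shows that the number at this position depends on what the nitrogen carries and not only on the presence of a nitrogen there. Going by these compounds alone, the earlier compounds offered ethylamino as the only nitrogen-linked group, and it stood apart from both hydroxy and chloro, whereas (1,3-thiazol-2-yl)amino does not: replacing chloro gives a 1.3-fold lower number from compound 2 to compound 4 (0.10 log units; within the scatter) and replacing hydroxy gives a 1.3-fold lower number from compound 1 to compound 4 (0.10 log units; within the scatter), both within the scatter. So the gap that compound 3 opened is not shared by every nitrogen-linked group at this aromatic carbon, though nothing measured on these compounds bears on why the two groups on the nitrogen differ.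

The compounds shown leave open whether the ring itself or its nitrogen and sulfur count here, which a phenyl or a cyclopentyl on that nitrogen could separate. Going by these compounds, it is also open whether a longer chain such as butyl, or a morpholine at this aromatic carbon, would fall with compound 3 or with compound 4.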